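This account rests on a few compounds, and the source may have more. Where it says the series, first, only, none or still open, it means among the compounds named here.

In a functional assay on MOLT-4 cells (Homo sapiens) (a lower number here means a stronger inhibitor, a higher number a weaker inhibitor), compound 2 (`OC[C@H]1C[C@@H](Cn2cnc3c(-c4ccc(Cl)cc4)ncnc32)c2ccccc21`) holds the lower of the two numbers at 0.63 ug/mL while compound 1 (`OC[C@H]1C[C@@H](Cn2cnc3c(Cl)ncnc32)c2ccccc21`) reads 24 ug/mL on the same scale. Compound 3 (`CCCNc1ncnc2c1ncn2C[C@@H]1C[C@H](CO)c2ccccc21`) has not yet been measured. It carries propylamino in place of 4-chlorophenyl on an aromatic carbon. Among the measured compounds shown here, the only measured step at that carbon (a 38-fold lower number from compound 1 to compound 2 (1.58 log units; beyond the scatter)) was large and beyond the scatter, and it brought in the 4-chlorophenyl that compound 3 gives up. For the measured compounds named here, no measured compound carries propylamino, so that step guides the direction better than the size. Much of its gain is expected to be lost, which would leave compound 3 a weaker inhibitor. The expected change is a 9.5-fold higher number from compound 2 to compound 3 (0.98 log units; beyond the scatter) towards a higher number, a large step beyond the scatter. In this assay compound 3 is therefore estimated at 6 ug/mL and is expected to fall between 1.5 ug/mL and 25 ug/mL.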

Compound 3, half-maximal inhibitory concentration: 24 ug/mL
Estimate against measurement, compound 3: 4.0-fold (0.60 log units) below; low and high end bracket the measured number.
By their numbers in this assay, from the lowest: compound 2; then compounds 1 and 3 (each within the scatter of the next).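

In this assay, propylamino at this aromatic carbon gives back the whole of the gain that 4-chlorophenyl brought (a 38-fold higher number from compound 2 to compound 3 (1.58 log units; beyond the scatter)), and it does not separate from chloro at the same carbon (no change at the digits printed from compound 1 to compound 3 (within the scatter)). Of the three groups seen here, only 4-chlorophenyl therefore stands apart, and replacing chloro with just any larger group is not enough to reproduce its step: propylamino has more heavy atoms than chloro yet reads level with it. No measurement at hand gives a reason for this difference.

The compounds shown leave open whether the chlorine on the ring matters, which plain phenyl would test, and whether another aromatic ring, such as pyridyl, would hold the gain. They also leave open whether a cyclic amine such as morpholine would behave like propylamino.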